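Terminal amine swap on the ether side chain

A few compounds are considered here, and "the series" means these few. Any claim that something is new, unique, unknown or untested is made for them only; others in the source may bear on it.

Among the compounds with values here, compound 2, `COc1cc2c(Oc3ccc(NC(=O)c4cn(-c5ccccc5)nn4)cc3F)ccnc2cc1OCCCN1CCC(C)CC1`, gives 190 nM in a functional assay on HT-29 cells (Homo sapiens) for cytotoxicity, read by MTT assay, with a stated time of 72 h (on this read-out higher numbers stand for weaker inhibition and lower numbers for stronger inhibition), which places it at the higher of the two numbers measured so far, with its neighbour compound 1, `COc1cc2c(Oc3ccc(NC(=O)c4cn(-c5ccccc5)nn4)cc3F)ccnc2cc1OCCCN1CCCC1`, close by at 180 nM. The step of a 1.1-fold higher number from compound 1 to compound 2 (0.02 log units; within the scatter) shows that exchanging one terminal amine for another at this position moved the read-out by no more than the assay scatter allows.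

Compound 3, `COc1cc2c(Oc3ccc(NC(=O)c4cn(-c5ccccc5)nn4)cc3F)ccnc2cc1OCCCN1CCN(C)CC1`, is the next candidate. Its difference from compound 2 is 4-methylpiperazin-1-yl in place of 4-methylpiperidin-1-yl on a saturated chain carbon, three bonds along the chain from an oxygen on an aromatic ring. Within the data shown here, the only measured step that bears on this change is the one from compound 1 to compound 2, which likewise replaced one saturated nitrogen-containing ring at the end of the three-carbon chain with another and came out within the scatter. On that basis a step of size a 1.1-fold higher number from compound 2 to compound 3 (0.02 log units; within the scatter) is expected in this assay, that is, no movement beyond the usual scatter in either direction. For compound 3 the estimated value in this assay is therefore 200 nM, with a range from 90 nM to 450 nM.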

Compound 3, half-maximal inhibitory concentration: 180 nM
Beside the measured number, compound 3's estimate is 1.1-fold (0.05 log units) above it; the measured number falls inside the stated range.
By their numbers in this assay, from the lowest: compounds 1, 3 and 2 (each within the scatter of the next).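

With compound 3, three different terminal rings have now been read at this position, on a saturated chain carbon, three bonds along the chain from an oxygen on an aromatic ring. In this assay, the step of a 1.1-fold lower number from compound 2 to compound 3 (0.02 log units; within the scatter) shows that the read-out stays within the scatter when 4-methylpiperazin-1-yl, with its second ring nitrogen and second hydrogen-bond acceptor, stands in place of 4-methylpiperidin-1-yl, and the step of no change at the digits printed from compound 1 to compound 3 (within the scatter) shows the same for 4-methylpiperazin-1-yl against pyrrolidin-1-yl, so that all three pairs among compound 1, compound 2 and compound 3 now lie within the scatter of one another. Nothing at hand offers a reason for this flat result.

Going by these compounds, all three compounds carry their ring on the same propyl chain, so it remains open whether the read-out would hold with a morpholin-4-yl ring, an open-chain dimethylamino group or a carboxylic acid at the chain end. On these data alone, it is equally open whether it would hold with a longer chain, or whether these rings would stay this close in any cell line other than the one in this assay.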